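Dropping a Trifluoromethyl Group: Expected Plasma Exposure

The source may report more compounds than this note shows. Statements on the series, on what has been measured and on what is new or still open speak of the compounds shown alone.

Compound 2 `C=CC(=O)Nc1cc(-n2c(=O)cc(C)c3cnc(Nc4ccc(N5CCN(C)C(C)C5)cc4OC)nc32)cc(C(F)(F)F)c1` was tested in an ADME assay on the whole organism (strain Sprague-Dawley) for pharmacokinetics, with Rattus norvegicus as the target, read by LC-MS, at a dose of 25 mg/kg by the oral route (on this read-out lower numbers stand for lower exposure and higher numbers for higher exposure at the dose given), where it gives 35.2 nM. Compound 1 `C=CC(=O)Nc1cccc(-n2c(=O)cc(C)c3cnc(Nc4ccccc4Nc4nc5c(s4)CN(C)CC5)nc32)c1`, which carries a different amine side chain on the shared core, gives 18.8 nM in this assay; the two numbers lie within the usual scatter of each other, so neither compound can be said to reach a higher exposure than the other. Compound 3 `C=CC(=O)Nc1cccc(-n2c(=O)cc(C)c3cnc(Nc4ccc(N5CCN(C)C(C)C5)cc4OC)nc32)c1` has not yet been measured. It differs from compound 2 in one place: hydrogen in place of trifluoromethyl on an aromatic carbon. Among the compounds with values here, no measured pair of compounds shows the effect of this particular change, so no step for it is known. In this assay the step is expected to be small, a 1.3-fold lower number from compound 2 to compound 3 (0.12 log units; within the scatter), with no direction beyond the scatter. For compound 3 a maximal plasma concentration of 27 nM is estimated, with a range from 9 nM to 80 nM.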

Compound 3, maximal plasma concentration: 287 nM
The estimate for compound 3 lay 11-fold (1.03 log units) below the measured number, outside the stated range (above it).
By their numbers in this assay, from the lowest: compounds 1 and 2 (each within the scatter of the next); then compound 3.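

This aromatic carbon, on the six-membered aromatic ring that also carries the (vinylcarbonyl)amino group, turns out to matter for exposure. In this assay, within the data shown here, hydrogen in place of trifluoromethyl gives an 8.2-fold higher number from compound 2 to compound 3 (0.91 log units; beyond the scatter) and so provides the first direct reading of this change, which compound 1 and compound 2 could not offer, as they differ in more than one place. Nothing in the data at hand explains why the maximal plasma concentration changes in this way.

From the compounds shown here alone, this is a single pair, so it remains open whether other small groups on this carbon, such as fluorine, chlorine or methyl, would behave like hydrogen or like trifluoromethyl. Among these compounds, it is also open whether the same change would give a similar step with a different amine side chain, such as the one on compound 1.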